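The compounds below may be only part of what the source reports. "The series", "measured", "known", "first", "only" and "open" are said of these compounds alone.

Among the measured compounds shown here, in a physicochemical assay for lipophilicity, using the shake flask method (on this read-out higher numbers stand for higher lipophilicity and lower numbers for lower lipophilicity), compound 1 (`CCc1cnc(-c2cc(Oc3ccc(S(C)(=O)=O)cc3)cc(OC(C)C)c2)[nH]c1=O`) gives 3.11, and compound 2 (`COc1cnc(-c2cc(Oc3ccc(S(C)(=O)=O)cc3)cc(OC(C)C)c2)[nH]c1=O`) gives 2.21, the lower of the two numbers so far. Compound 3 (`CC(C)Oc1cc(Oc2ccc(S(C)(=O)=O)cc2)cc(-c2ncc(Cl)c(=O)[nH]2)c1`) has not yet been measured. It carries chloro in place of methoxy on an aromatic carbon of a six-membered aromatic ring with 2 nitrogen (chloro in place of methoxy on an aromatic carbon). For the measured compounds named here, only one measured step bears on this change: with methoxy in place of ethyl on an aromatic carbon, the result was a number 0.90 log units lower from compound 1 to compound 2 (beyond the scatter), a modest step beyond the scatter. Going by the values given here, no measured compound carries chloro, so that step gives only a rough guide to size, and a modest rise from compound 2 seems likely, smaller than the measured gap. In this assay the estimated change is a number 0.39 log units higher from compound 2 to compound 3 (beyond the scatter). The expected value for compound 3 is 2.6, with an estimated range of 2.15 to 3.05.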

Compound 3, distribution coefficient: 2.04
Compound 3: middle estimate off by 0.56 log units, on the high side; the measured number lies below the stated range.
By their numbers in this assay, from the lowest: compounds 3 and 2 (each within the scatter of the next); then compound 1.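

In this assay, chloro in place of methoxy on an aromatic carbon gives a number 0.17 log units lower from compound 2 to compound 3 (within the scatter) and so leaves the two groups indistinguishable at this position, even though methoxy brings 2 heavy atoms and 1 hydrogen-bond acceptor while chloro brings 1 heavy atom and 0 hydrogen-bond acceptors. Chloro in place of ethyl on an aromatic carbon gives a number 1.07 log units lower from compound 1 to compound 3 (beyond the scatter) and shows that, of the three groups, ethyl alone stands apart, with compound 2 and compound 3 together on the low side. Nothing available gives a cause for this grouping.

Going by these compounds, it remains open whether an amine or a carboxylic acid at this position would fall with compound 2 and compound 3 or nearer compound 1. On these data alone, it is also open whether a longer chain such as propyl would lie beyond compound 1.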